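The source may hold more compounds than are shown below. What is called first, only, known or untested is meant among the compounds shown, and "the series" means these compounds.

In an ADME assay on BJ cells (Homo sapiens) for cytotoxicity, read by luminescence, with a stated time of 72 h (on this read-out lower numbers stand for an effect already at smaller amounts and higher numbers for an effect only at larger amounts of compound), three compounds of the same series have been examined. Compound 1 `CCOC(=O)c1c(-c2cccc(OC)c2)[nH]c2cc(Cl)c(Cl)cc2c1=O` carries a methoxy group on its pendant ring. In this assay compound 1 gives > 21500 nM, which is a limit of the assay rather than a number. Compound 2 `CCOC(=O)c1c(-c2cccc(Oc3ccccc3)c2)[nH]c2cc(Cl)c(Cl)cc2c1=O` differs from compound 1 by phenyl in place of methyl on an oxygen on an aromatic ring. In this assay compound 2 gives > 21500 nM, again a limit. The step that the two limits leave unreadable from compound 1 to compound 2 therefore cannot be read in size, because both values sit at the limit of > 21500 nM in this assay, at which 3 of the 3 values shown sit. Compound 3 `CCOC(=O)c1c(-c2cccc(OC)c2)[nH]c2cc(OC)c(F)cc2c1=O` has a different core; the difference between the two cores is not broken down here. In this assay compound 3 gives > 21500 nM, also a limit.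

Compound 4 `CCOC(=O)c1c(-c2cccc(Oc3ccccc3)c2)[nH]c2cc(OC)c(F)cc2c1=O` has not been measured. It differs from compound 3 by phenyl in place of methyl on an oxygen on an aromatic ring, the same change that leads from compound 1 to compound 2. Since all three measured compounds sit at the limit of > 21500 nM in this assay, at which 3 of the 3 values shown sit, compound 4 is expected to behave alike, with an estimated 30000 nM and a range from 15000 nM to 100000 nM. The step from compound 3 to compound 4 is expected to be a step that the limit leaves unreadable from compound 3 to compound 4.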

Compound 4, half-maximal effective concentration: > 21500 nM
Compound 4 ended at the assay's limit; the forecaster's own chance of this, stated with the estimate: 85%; the middle value lies beyond the limit too.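

The step from compound 3 to compound 4 cannot be read in size, because both compounds sit at the same limit of the assay rather than at a number: the limit of > 21500 nM in this assay, at which 4 of the 4 values shown sit.

The compounds shown leave open at which concentration any of them would reach a half-maximal effect in this assay, and whether methoxy and phenoxy differ there at all.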